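The source may report more compounds than this note shows. Statements on the series, on what has been measured and on what is new or still open speak of the compounds shown alone.

Compound 1 `CC(C)c1ccc2c(Nc3cc(C(=O)N[C@@](C)(CO)c4ccccc4)ccc3Sc3ccc(N)cc3)ncnc2n1` gives 12.5 mL/min/kg in an ADME assay on the whole organism (strain Sprague-Dawley) for pharmacokinetics, with Rattus norvegicus as the target, at a dose of 5 mg/kg by the intravenous route; a higher number here means faster removal of the compound, a lower number slower removal.
Compound 2 `COC(=O)Nc1ccc(Sc2ccc(C(=O)N[C@@H](C)c3ccccc3)cc2Nc2ncnc3nc(C(C)C)ccc23)cc1` gives 12.8 mL/min/kg in this assay.
Compound 3 `Cc1ccc([C@H](C)NC(=O)c2ccc(Sc3ccc(N)cc3)c(Nc3ncnc4nc(C(C)C)ccc34)c2)cc1` gives 18.3 mL/min/kg in this assay.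

In this assay the three numbers all lie within the scatter of one another; the number for compound 3 is nominally the top one, but the step of a 1.5-fold higher number from compound 1 to compound 3 (0.17 log units; within the scatter) is within the scatter, and the gap between compound 2 and compound 3 is within the scatter as well. Compound 2 differs from compound 3 in more than one place, so only its value can be set beside that of compound 3.

Compound 4 `CC(C)c1ccc2c(Nc3cc(C(=O)N[C@@H](C)C4CCCCC4)ccc3Sc3ccc(N)cc3)ncnc2n1` differs from compound 3 by cyclohexyl in place of 4-methylphenyl on a saturated chain carbon bound to an amide-type nitrogen and a saturated chain carbon. Among the compounds with values here, the one measured step that touches the same amide-type nitrogen is a 1.5-fold higher number from compound 1 to compound 3 (0.17 log units; within the scatter), which exchanged a different pair of groups there and stayed within the scatter. Within the data shown here, no measured pair shows an aromatic ring giving way to a saturated ring at this carbon. On this basis no step beyond the scatter is expected in this assay, and the step of a 1.0-fold lower number from compound 3 to compound 4 (0.01 log units; within the scatter) is the estimate. Compound 4 is therefore expected to give about 18 mL/min/kg in this assay, within a range from 9 mL/min/kg to 36 mL/min/kg.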

Compound 4, clearance: 21.5 mL/min/kg
The estimate for compound 4 lay 1.2-fold (0.08 log units) below the measured number; the range from low to high includes it.
By their numbers in this assay, from the lowest: compounds 1, 2, 3 and 4 (each within the scatter of the next).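

In this assay the exchange of an aromatic ring for a non-aromatic ring on this carbon now has a measured step: cyclohexyl in place of 4-methylphenyl on a saturated chain carbon bound to an amide-type nitrogen and a saturated chain carbon gives a 1.2-fold higher number from compound 3 to compound 4 (0.07 log units; within the scatter) and so does not separate the two compounds. The larger exchange on the amide-type nitrogen, 1-cyclohexylethyl in place of 1-(hydroxymethyl)-1-phenylethyl, gives a 1.7-fold higher number from compound 1 to compound 4 (0.24 log units; within the scatter) and also stays inside the scatter. Nothing available explains why these numbers stay so close.

On these data alone, whether an amine or a carboxylic acid in place of cyclohexyl on this carbon would give a step beyond the scatter remains open. The same holds for a longer chain on the amide-type nitrogen.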